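This account rests on a few compounds, and the source may have more. Where it says the series, first, only, none or still open, it means among the compounds named here.

Measured so far in an ADME assay on microsomes from liver (Rattus norvegicus) for metabolic stability; a higher number here means that the compound lasts longer, a lower number that the compound disappears faster:
- compound 1 `Cn1nc2c(=O)n(CC3(O)CCN(Cc4ccc(-c5ccco5)cc4Cl)CC3)cnc2c1-c1ccc(C2(N)CC2)cc1`: 0.617 h
- compound 2 `Cn1nc2c(=O)n(CC3(O)CCN(Cc4ccc(-c5cnco5)cc4Cl)CC3)cnc2c1-c1ccc(CN)cc1`: 3.85 h
- compound 3 `Cn1nc2c(=O)n(CC3(O)CCN(Cc4ccc(-c5ccco5)cc4Cl)CC3)cnc2c1-c1ccc(CNCCO)cc1`: 1.52 h

Compound 3 holds the middle place among these three numbers, with compound 1 lower and compound 2 higher. The next compound, compound 4 `CNCc1ccc(-c2c3ncn(CC4(O)CCN(Cc5ccc(-c6ccco6)cc5Cl)CC4)c(=O)c3nn2C)cc1`, comes from compound 3 through one small edit: hydrogen in place of hydroxymethyl on a saturated chain carbon bound to an amine nitrogen. Put simply, this is hydrogen in place of hydroxymethyl on a saturated chain carbon bound to an amine nitrogen, so 2-hydroxyethyl becomes methyl.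

No measurement covers this exact edit. The nearest evidence is a 2.5-fold higher number from compound 1 to compound 3 (0.39 log units; beyond the scatter), a modest step that exchanged a whole side group, 1-aminocyclopropyl for ((2-hydroxyethyl)amino)methyl. Compound 2 differs from compound 3 in more than one place, so it cannot isolate the edit. A smaller edit is therefore expected to move this assay less than that step did, perhaps slightly downward and probably within the scatter. The expected step is a 1.2-fold lower number from compound 3 to compound 4 (0.07 log units; within the scatter). The estimate for compound 4 is 1.3 h, with an expected range from 0.6 h to 2.8 h.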

Compound 4, half-life: 0.533 h
The estimate for compound 4 lay 2.4-fold (0.39 log units) above the measured number; the whole stated range lies above it.
By their numbers in this assay, from the lowest: compounds 4 and 1 (each within the scatter of the next); then compound 3; then compound 2.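

In this assay, cutting hydroxymethyl from the saturated chain carbon bound to the amine nitrogen, so that 2-hydroxyethyl becomes methyl, gives a 2.9-fold lower number from compound 3 to compound 4 (0.46 log units; beyond the scatter) and shows that even this small edit can move the half-life beyond the scatter. With (methylamino)methyl in place of 1-aminocyclopropyl there is a 1.2-fold lower number from compound 1 to compound 4 (0.06 log units; within the scatter), so among these compounds the higher number of compound 3 goes with the hydroxymethyl end of its chain and not with the change of side group alone. Nothing available explains why this edit changes the number.

From the compounds shown here alone, it remains open whether the hydroxyl group itself matters or whether the length of the chain does. An ethyl or a 2-methoxyethyl group on the same amine nitrogen would help separate these two readings.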